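The source may hold more compounds than are shown below. What is called first, only, known or untested is meant among the compounds shown, and "the series" means these compounds.

In an ADME assay on the whole organism (strain CD1) for pharmacokinetics, with Mus musculus as the target, read by LC-MS, at a dose of 5 mg/kg by the intravenous route (a lower number here means less compound in the circulation, a higher number more compound in the circulation at the dose given), compound 1 (`Cc1c(Oc2cnc(C(=O)NC(C)CO)cn2)ccc2c1B(O)OC2`) gives 39000 ng.h/mL, compound 2 (`CCC[C@H](CO)NC(=O)c1cnc(Oc2ccc3c(c2C)B(O)OC3)cn1`) gives 20500 ng.h/mL and compound 3 (`Cc1c(Oc2cnc(C(=O)N[C@@H](CO)CC(F)(F)F)cn2)ccc2c1B(O)OC2`) gives 21000 ng.h/mL. Compound 3 therefore sits within the scatter of both others. The three differ only in the side chain on the amide nitrogen, and those swaps did little: a 1.9-fold lower number from compound 1 to compound 2 (0.28 log units; within the scatter), a 1.9-fold lower number from compound 1 to compound 3 (0.27 log units; within the scatter) and a 1.0-fold higher number from compound 2 to compound 3 (0.01 log units; within the scatter) all stay within the scatter. Compound 4 (`Cc1c(Oc2cnc(C(=O)N3CC(C)(O)C3)cn2)ccc2c1B(O)OC2`) goes further, with this difference: 3-hydroxy-3-methylazetidin-1-yl in place of (3,3,3-trifluoro-1-(hydroxymethyl)propyl)amino on a carbonyl carbon. For the measured compounds named here, the amide nitrogen now belongs to a four-membered non-aromatic ring, which no measured compound carries, and that leaves the range wide. On the small steps seen so far, the expected change in this assay is a 1.1-fold lower number from compound 3 to compound 4 (0.02 log units; within the scatter), nothing beyond the scatter. For compound 4 the estimate is 20000 ng.h/mL, with an expected range of 8000 ng.h/mL to 45000 ng.h/mL.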

Compound 4, area under the concentration-time curve: 20500 ng.h/mL
Estimate against measurement, compound 4: 1.0-fold (0.01 log units) below; measured number inside the range.
By their numbers in this assay, from the lowest: compounds 2, 4, 3 and 1 (each within the scatter of the next).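

Replacing the open side chains with 3-hydroxy-3-methylazetidin-1-yl, a four-membered non-aromatic ring, on the carbonyl carbon leaves this assay within the scatter for all three comparisons (a 1.0-fold lower number from compound 3 to compound 4 (0.01 log units; within the scatter)), (no change at the digits printed from compound 2 to compound 4 (within the scatter)) and (a 1.9-fold lower number from compound 1 to compound 4 (0.28 log units; within the scatter)). The amide nitrogen can therefore sit in a ring without a step beyond the scatter, even with fewer heavy atoms and hydrogen-bond donors than compound 3 and no defined stereocentre. Nothing shown explains this lack of change. As far as these compounds go, whether a side chain carrying an amine or a carboxylic acid instead of the hydroxyl would give a step beyond the scatter remains open.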